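A Thiourea Swap Tested on a Second Core

This account rests on a few compounds, and the source may have more. Where it says the series, first, only, none or still open, it means among the compounds named here.

Of the compounds shown here, three have so far been measured in a functional assay on HeLa cells (Homo sapiens) for inhibition, read by CCK-8 assay, with a stated time of 48 h; a lower number here means a stronger inhibitor, a higher number a weaker inhibitor. Compound 3 `CC(C)c1ccc(Oc2ccc(O)c(O)c2)c(-c2ccsc2S(=O)(=O)NCCNC(=O)Nc2cc(Cl)cc(Cl)c2)c1` carries a (3,5-dichlorophenyl)carbamoyl group on an amine nitrogen whose other neighbour is a saturated chain carbon. In this assay compound 3 gives > 50000 nM, which is a limit of the assay and not a number. Compound 1 `CC(C)c1ccc(Oc2ccc(O)c(O)c2)c(-c2ccsc2S(=O)(=O)NCCNC(=S)Nc2ccc([N+](=O)[O-])cc2)c1` differs from compound 3 by a group of 12 heavy atoms (7 carbon, 2 nitrogen, 2 oxygen, 1 sulfur; one six-membered aromatic ring of carbon only) in place of a group of 11 heavy atoms (7 carbon, 1 nitrogen, 1 oxygen, 2 chlorine; one six-membered aromatic ring of carbon only), on an amine nitrogen. In this assay compound 1 gives > 20000 nM, again a limit. The step that the two limits leave unreadable from compound 3 to compound 1 cannot be read because the limit of > 50000 nM in this assay, at which 1 of the 3 values shown sits, and the limit of > 20000 nM in this assay, at which 2 of the 3 values shown sit, sit at both of its ends.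

Compound 2 `O=C(NCCNS(=O)(=O)c1ccc(-c2ccccc2O[C@H]2CC[C@H](O)CC2)s1)Nc1cc(Cl)cc(Cl)c1` is built on another core; the difference between the two cores is not broken down here. In this assay compound 2 gives > 20000 nM, which is a limit of the assay. Compound 4 `O=[N+]([O-])c1ccc(NC(=S)NCCNS(=O)(=O)c2ccc(-c3ccccc3O[C@H]3CC[C@H](O)CC3)s2)cc1` has not been measured. For the measured compounds named here, it differs from compound 2 by a group of 12 heavy atoms (7 carbon, 2 nitrogen, 2 oxygen, 1 sulfur; one six-membered aromatic ring of carbon only) in place of a group of 11 heavy atoms (7 carbon, 1 nitrogen, 1 oxygen, 2 chlorine; one six-membered aromatic ring of carbon only), on an amine nitrogen, the same change, at the same kind of place, as the one from compound 3 to compound 1.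

Since that change gave no readable step on the first core, it is expected to be small here as well, with compound 4 estimated at a step that the limit leaves unreadable from compound 2 to compound 4. In this assay compound 4 is expected to give about 30000 nM, estimated between 10000 nM and 100000 nM, and most probably only a limit will be reported. This rests on compound 2, whose value > 20000 nM is a limit.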

Compound 4, half-maximal inhibitory concentration: 5400 nM
For compound 4 the middle estimate is 5.6-fold (0.74 log units) above the measured one; the measured number lies below the stated range.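

In this assay, the thiourea swap on the core of compound 2 gives an at least 3.7-fold lower number from compound 2 to compound 4 (0.56 log units; beyond the scatter), so on this core the change goes with a real drop in the number, one that lies beyond the usual scatter. For compound 2, > 20000 nM is a limit of the assay and not a number. The same swap on the core of compound 3 cannot be read, so this is a single readable step on a single core, and it shows neither that the change carries over from one core to the other nor that its outcome depends on the core.

The swap also alters two things at once, a carbonyl becoming a thiocarbonyl and two chlorines giving way to a nitro group, and no compound shown holds one of these without the other, so which part goes with the step stays open. Also open, from the compounds shown here alone, is how the step would read with other groups on that aromatic ring, such as an amine or a carboxylic acid, or with a longer chain in place of the saturated chain on the amine nitrogen.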